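Chain extension of the ester side chain toward compound 3

The compounds below may be only part of what the source reports. "The series", "measured", "known", "first", "only" and "open" are said of these compounds alone.

Compound 1 `CC(C)[C@H](NC(=O)CN(c1nc(Cl)nc2[nH]cnc12)C1CC1)C(=O)OCc1ccccc1` and compound 2 `O=C(CN(c1nc(Cl)nc2[nH]cnc12)C1CC1)N[C@@H](CC(=O)OCc1ccccc1)C(=O)OCc1ccccc1` share one core and differ only in the group on the saturated chain carbon bound to an amide-type nitrogen and a carbonyl carbon. In a functional assay on the whole organism (Tail, strain ICR) with Mus musculus as the target, in the tail flick test, with a stated time of 120 min, at a dose of 25 umol/kg by the oral route (a higher number here means a stronger effect of the compound at the dose given, a lower number a weaker effect), compound 1 gives 27.3%, and compound 2 gives 12.1%. Going by the values given here, compound 2 thus stands lowest of the two numbers so far; its nearest neighbour is compound 1, and the step of a number 15.2 percentage points lower from compound 1 to compound 2 (beyond the scatter) puts that gap beyond the scatter.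

Compound 3 `O=C(CN(c1nc(Cl)nc2[nH]cnc12)C1CC1)N[C@@H](CCC(=O)OCc1ccccc1)C(=O)OCc1ccccc1` is the next member. Its change from compound 2 is (benzyloxycarbonyl)methyl in place of benzyloxycarbonyl on a saturated chain carbon, two bonds along the chain from an amide-type nitrogen and a carbonyl carbon. Among the compounds with values here, no measured step tests this kind of change, the lengthening from (benzyloxycarbonyl)methyl to 2-(benzyloxycarbonyl)ethyl; the only step in hand, a number 15.2 percentage points lower from compound 1 to compound 2 (beyond the scatter), concerns the swap of isopropyl for the ester-bearing chain and was modest. Keeping the ester-bearing chain and extending it is expected to move the read-out little, if at all, in this assay. For compound 3 the estimate in this assay is 14%, with a range of 3% to 30%. This means an expected step of a number 1.9 percentage points higher from compound 2 to compound 3 (within the scatter) that stays within the scatter.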

Compound 3, a percentage reported as activity, at one dose (the size of the read-out at that dose, not a potency): 45.9%
Compound 3: the middle estimate sits 31.9 percentage points below what was measured; the whole stated range lies below it.
By their numbers in this assay, from the lowest: compound 2; then compound 1; then compound 3.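

In this assay, going by these compounds alone, the ester-bearing chain at this position turns out to be sensitive to its length alone: with the benzyl ester kept, going from (benzyloxycarbonyl)methyl to 2-(benzyloxycarbonyl)ethyl gives a number 33.8 percentage points higher from compound 2 to compound 3 (beyond the scatter) and is the largest step so far. Measured against the isopropyl compound, the 2-(benzyloxycarbonyl)ethyl chain gives a number 18.6 percentage points higher from compound 1 to compound 3 (beyond the scatter) and so reverses the direction seen with the shorter chain of compound 2. Among these three compounds, then, carrying an ester-bearing chain does not by itself set the direction of the change from isopropyl, and the read-out at this single dose and time depends on how that chain is built.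

Still open, on these data alone, is whether a longer chain such as 3-(benzyloxycarbonyl)propyl raises the read-out further or reverses it, and whether a free carboxylic acid or a primary amide in place of the benzyl ester on the 2-(benzyloxycarbonyl)ethyl chain keeps the effect. Nothing available on these compounds bears on why one added chain carbon produces a step of this size.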